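A few compounds are considered here, and "the series" means these few. Any claim that something is new, unique, unknown or untested is made for them only; others in the source may bear on it.

In an assay on HepG2 cells for agonist activity at nuclear receptor subfamily 1 group I member 3 (Homo sapiens), read by a luciferase reporter, with a stated time of 23 h (a higher number here means that more compound is needed for the effect, a lower number that less compound is needed), compound 2 `CC(C)(C)c1ccc(CO/N=C/c2c(-c3ccc4ccccc4c3)nc3occn23)cc1` gives 7900 nM, the highest number of the three measured compounds. Compound 1 `Clc1ccc(CO/N=C/c2c(-c3ccc4ccccc4c3)nc3occn23)cc1Cl` gives 370 nM and compound 3 `Fc1c(F)c(F)c(CO/N=C/c2c(-c3ccc4ccccc4c3)nc3occn23)c(F)c1F` gives 1700 nM. The step from compound 2 to compound 4 `C(=N/OCc1ccc(Oc2ccccc2)cc1)\c1c(-c2ccc3ccccc3c2)nc2occn12` is phenoxy in place of tert-butyl on an aromatic carbon, the place being para to a large group. Two measured steps involve compound 2 and both exchange the same aryl group: a 21-fold higher number from compound 1 to compound 2 (1.33 log units; beyond the scatter) and a 4.6-fold lower number from compound 2 to compound 3 (0.67 log units; beyond the scatter). Among the measured compounds shown here, in both cases the partner without tert-butyl shows the lower number, so a decrease is expected for compound 4 as well, though phenoxy matches neither of those groups and the direction rests on only two steps. Compound 4 is therefore expected near 2500 nM, within 600 nM to 10000 nM, a step estimated as a 3.2-fold lower number from compound 2 to compound 4 (0.50 log units; beyond the scatter).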

Compound 4, half-maximal effective concentration: "not active" (no number reported)
For compound 4 the study gives words and no number, so the estimate cannot be set against anything.
By their numbers in this assay, from the lowest: compound 1; then compound 3; then compound 2.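

In this assay, among the compounds shown here, compound 4 is reported only as "not active", without a number, so no step linking it to compound 1, compound 2 or compound 3 can be read. From the compounds shown here alone, how phenoxy in place of tert-butyl shifts the number remains open. Nothing shown accounts for this result.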